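Methoxy for hydroxyethyl on a shared agonist core

This account rests on a few compounds, and the source may have more. Where it says the series, first, only, none or still open, it means among the compounds named here.

Compound 1 `CC(O)c1cnc(N2CCC(c3coc4c(N5CCc6cc(S(C)(=O)=O)ccc65)ncnc34)CC2)nc1`: 586 nM in a functional assay on cells for agonist activity at Glucose-dependent insulinotropic receptor (Homo sapiens), read by a luciferase reporter, with a stated time of 4 h; on this read-out higher numbers stand for an effect only at larger amounts of compound and lower numbers for an effect already at smaller amounts.
Compound 2 `CN(c1ccc(S(C)(=O)=O)cc1F)c1ncnc2c(C3CCN(C(=O)OC(C)(C)C)CC3)coc12`: > 1000 nM in this assay, a limit and not a number.
Compound 3 `Cn1cc(C2CCN(C(=O)OC(C)(C)C)CC2)c2ncnc(Nc3ccc(S(C)(=O)=O)cc3F)c21`: > 1000 nM in this assay, again a limit.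

Going by the values given here, compound 1 therefore stands alone with the only number recorded, since the other two values sit at the limit of > 1000 nM in this assay, at which 2 of the 3 values shown sit. Compound 2 and compound 3 also share a different core and give no guidance on the change in hand. Compound 4 `COc1cnc(N2CCC(c3coc4c(N5CCc6cc(S(C)(=O)=O)ccc65)ncnc34)CC2)nc1` differs from compound 1 by methoxy in place of 1-hydroxyethyl on an aromatic carbon. Among the compounds with values here, no measured pair shows this change, so a step within the usual scatter is expected, with no clear direction. Compound 4 is estimated at 650 nM, between 200 nM and 2000 nM, which means an expected step of a 1.1-fold higher number from compound 1 to compound 4 (0.05 log units; within the scatter).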

Compound 4, half-maximal effective concentration: 310 nM
The estimate for compound 4 lay 2.1-fold (0.32 log units) above the measured number, within the range that was stated.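

Going by these compounds alone, the change of methoxy for 1-hydroxyethyl gives a 1.9-fold lower number from compound 1 to compound 4 (0.28 log units; within the scatter) in this assay on the shared core, the first direct reading at this position. The group that leaves carries a hydrogen-bond donor and methoxy carries none, yet compound 4 still gives a number on this read-out, so a donor in this group is not required for that. Nothing measured here gives a reason for the step. From the compounds shown here alone, whether an amine, a carboxylic acid or a longer chain such as ethoxy would hold up at this position stays open. A single step also cannot show how far this result extends to other groups.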